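From benzoyl to cyclohexylcarbamoyl on a shared core

The compounds below may be only part of what the source reports. "The series", "measured", "known", "first", "only" and "open" are said of these compounds alone.

Measured in a functional assay on K562 cells (Homo sapiens) for antiproliferative activity, read by MTT assay (a lower number here means a stronger inhibitor, a higher number a weaker inhibitor), so far:
- Compound 1 `CCCOC(=O)N1CCCc2cc(S(=O)(=O)N3CC(c4ccccc4)NC3=O)ccc21` gives > 20000 nM (a limit of the assay, not a number)
- Compound 2 `CC(C)COC(=O)N1CCCc2cc(S(=O)(=O)N3CC(c4ccccc4)NC3=O)ccc21` gives 2380 nM
- Compound 3 `O=C(c1ccccc1)N1CCCc2cc(S(=O)(=O)N3CC(c4ccccc4)NC3=O)ccc21` gives 1220 nM

The number for compound 3 lies within the scatter of compound 2, and only compound 1 stands clearly apart from it. The next structure is compound 4 `O=C(NC1CCCCC1)N1CCCc2cc(S(=O)(=O)N3CC(c4ccccc4)NC3=O)ccc21`, in which cyclohexylamino takes the place of phenyl on a carbonyl carbon cyclohexylamino in place of phenyl on a carbonyl carbon in the same spot.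

Two measured swaps on this carbonyl carbon bear on the change. One, a 2.0-fold lower number from compound 2 to compound 3 (0.29 log units; within the scatter), stayed within the scatter. The other, an at least 16-fold lower number from compound 1 to compound 3 (1.21 log units; beyond the scatter), was large. Small edits in this group can also matter, as an at least 8.4-fold lower number from compound 1 to compound 2 (0.92 log units; beyond the scatter) shows for a single added methyl. Going by the values given here, no measured compound carries cyclohexylamino, so the uncertainty is wide. A small move toward a weaker number is expected, with no clear step beyond the scatter. The expected change is a 1.8-fold higher number from compound 3 to compound 4 (0.26 log units; within the scatter) in this estimate. For compound 4 the estimated value is 2200 nM, with an expected range from 600 nM to 9000 nM as the likely span.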

Compound 4, half-maximal inhibitory concentration: 813 nM
The estimate for compound 4 lay 2.7-fold (0.43 log units) above the measured number; measured number inside the range.
By their numbers in this assay, from the lowest: compounds 4, 3 and 2 (each within the scatter of the next, the first and the last beyond it). At a limit, above all of these: compound 1.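

On this carbonyl carbon, cyclohexylamino and phenyl cannot be told apart in this assay: the swap gives a 1.5-fold lower number from compound 3 to compound 4 (0.18 log units; within the scatter), so among these compounds an aromatic ring is not needed here. The change from isobutoxy to cyclohexylamino, a 2.9-fold lower number from compound 2 to compound 4 (0.47 log units; beyond the scatter), goes beyond the scatter, whereas the change from isobutoxy to phenyl stayed within it. The third step, an at least 24-fold lower number from compound 1 to compound 4 (1.39 log units; beyond the scatter), starts from a limit and not from a number: the limit of > 20000 nM in this assay, at which 1 of the 4 values shown sits.

Still open, from the compounds shown here alone, is how a smaller ring or an open chain on that nitrogen, such as cyclopentylamino or butylamino, would read. Phenylamino would also help, because the step to cyclohexylamino changes the ring and adds the nitrogen at once, and the compounds shown cannot separate the two.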